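The source may report more compounds than this note shows. Statements on the series, on what has been measured and on what is new or still open speak of the compounds shown alone.

Going by the values given here, compound 1 `CC(C)(CCCCF)[C@H](O)/C=C/[C@H]1COC(=O)N1CCSc1nc(C(=O)O)cs1` is one of two compounds measured in an assay on isolated protein for agonist activity at prostaglandin E2 receptor EP4 subtype (Homo sapiens); a lower number here means that less compound is needed, a higher number that more compound is needed for the effect. In this assay compound 1 gives 1220 nM, the higher of the two numbers. The other compound, compound 2 `CCCC[C@H](C)C[C@H](O)/C=C/[C@H]1CCC(=O)N1CCSc1nc(C(=O)O)cs1`, gives 3 nM in this assay. Among the compounds with values here, compound 2 differs from compound 1 in more than one place, and the two values show only that compound 1 sits far above compound 2, well beyond the scatter. Compound 3 `CCOCCC1([C@H](O)/C=C/[C@H]2COC(=O)N2CCSc2nc(C(=O)O)cs2)CCC1` has not yet been measured. It differs from compound 1 by a single change: 1-(2-ethoxyethyl)cyclobutyl in place of 5-fluoro-1,1-dimethylpentyl on a saturated chain carbon bound to a double-bonded chain carbon and an oxygen on a saturated carbon. The shared core of compound 1 is kept. Within the data shown here, no single-change step among the measured compounds exists to set this change against. The entering group carries one hydrogen-bond acceptor where the leaving group carried none, and the two groups are close in size. A moderate fall in the number is expected, a 3.1-fold lower number from compound 1 to compound 3 (0.48 log units; beyond the scatter). Compound 3 is thus estimated to give about 400 nM in this assay, within a range of 60 nM to 3000 nM.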

Compound 3, half-maximal effective concentration: 745 nM
For compound 3 the middle estimate is 1.9-fold (0.27 log units) below the measured one; the range from low to high includes it.
By their numbers in this assay, from the lowest: compound 2; then compounds 3 and 1 (each within the scatter of the next).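

At the saturated chain carbon bound to a double-bonded chain carbon and an oxygen on a saturated carbon, putting 1-(2-ethoxyethyl)cyclobutyl in place of 5-fluoro-1,1-dimethylpentyl gives a 1.6-fold lower number from compound 1 to compound 3 (0.21 log units; within the scatter) in this assay. Going by these compounds alone, this is the first single-change reading at this position, since compound 1 and compound 2 differ in more than one place. It shows that this exchange, which brings in a four-membered carbon ring and a hydrogen-bond acceptor and removes the fluorine, leaves compound 3 and compound 1 indistinguishable in this assay.

Going by these compounds, whether the ring or the oxygen alone would read the same stays open, as does whether an amine or a carboxylic acid on this chain would shift the number beyond the scatter. Nothing measured here bears on why these two groups read alike.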